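A few compounds are considered here, and "the series" means these few. Any claim that something is new, unique, unknown or untested is made for them only; others in the source may bear on it.

Measured in a functional assay on SK-OV-3 cells (Homo sapiens) for antiproliferative activity, read by MTT assay, with a stated time of 72 h; a higher number here means a weaker inhibitor, a lower number a stronger inhibitor:
- compound 1 `CC(C)(C)c1ccc(NC(=O)CCc2cccc3c2B(O)OC3)cc1`: 4200 nM
- compound 2 `CC(C)(C)OC(=O)Nc1ccc(NC(=O)CCc2cccc3c2B(O)OC3)cc1`: > 100000 nM (a limit of the assay, not a number)
- compound 3 `CC(C)c1cccc(NC(=O)CCc2cccc3c2B(O)OC3)c1`: 510 nM

Compound 3, at 510 nM, holds the lowest of the two actual numbers, while compound 1 gives 4200 nM, a gap beyond the scatter. The next compound to consider is compound 4 `O=C(CCc1cccc2c1B(O)OC2)Nc1cccc(-c2cccc(Cl)c2)c1`, which carries 3-chlorophenyl in place of isopropyl on an aromatic carbon, meta to a large group (3-chlorophenyl in place of isopropyl on an aromatic carbon).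

Among the compounds with values here, only one measured step bears on this change, and it is large: an at least 23-fold higher number from compound 1 to compound 2 (1.37 log units; beyond the scatter), with (tert-butoxycarbonyl)amino in place of tert-butyl on an aromatic carbon. That step ends at the limit of > 100000 nM in this assay, at which 1 of the 3 values shown sits. It involves other groups than the present change, so it marks a risk of a large rise in this assay without fixing a size or a direction for compound 4. No shift beyond the scatter is therefore expected, and the range is kept wide on both sides. The expected step is a 1.5-fold lower number from compound 3 to compound 4 (0.16 log units; within the scatter). The estimate for compound 4 is 350 nM, with an expected range from 50 nM to 3500 nM.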

Compound 4, half-maximal inhibitory concentration: 300 nM
Compound 4: middle estimate off by 1.2-fold (0.07 log units), on the high side; the measured number falls inside the stated range.
By their numbers in this assay, from the lowest: compounds 4 and 3 (each within the scatter of the next); then compound 1. At a limit, above all of these: compound 2.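

In this assay, the aromatic carbon that carries isopropyl in compound 3 also tolerates 3-chlorophenyl, which brings 7 heavy atoms and a six-membered aromatic ring in place of 3 heavy atoms and no ring: a 1.7-fold lower number from compound 3 to compound 4 (0.23 log units; within the scatter). Within the data shown here, a much larger aromatic substituent at this place therefore leaves the number within the scatter, something the only earlier step, an at least 23-fold higher number from compound 1 to compound 2 (1.37 log units; beyond the scatter), with (tert-butoxycarbonyl)amino in place of tert-butyl, could not show. Nothing measured here bears on the mechanism behind this tolerance, and no cause is assigned to the step.

Open, from the compounds shown here alone, is whether the chlorine contributes anything in this assay, and whether a plain phenyl at this place would read the same as the 3-chlorophenyl group of compound 4. Also open, going by these compounds, is how far this tolerance extends, for instance to a pyridine ring, or to an added ring bearing an amine or a carboxylic acid in place of the chlorine.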